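Chloro in place of cyano in a weakly active series

A few compounds are considered here, and "the series" means these few. Any claim that something is new, unique, unknown or untested is made for them only; others in the source may bear on it.

Compound 1 `CSCC[C@H](NC(=O)c1ccc(NCc2cncn2Cc2cccc(C#N)c2)cc1-c1ccccc1)C(=O)O` was examined in a functional assay on NIH3T3 cells (Mus musculus); on this read-out lower numbers stand for an effect already at smaller amounts and higher numbers for an effect only at larger amounts of compound. In this assay compound 1 gives only a limit, > 10 uM, and not a number. Compound 2 `CSCNC(=O)c1ccc(NCc2cncn2Cc2ccc(C#N)cc2)cc1-c1ccccc1` likewise gives only a limit in this assay, > 10 uM. Compound 3 `CCOC(=O)[C@H](CCSC)NC(=O)c1ccc(CNCc2c[nH]cn2)cc1-c1ccccc1C` gives 10 uM in this assay. Within the data shown here, all three values therefore sit at the weak end, and the only evidence for the series is the limit of > 10 uM in this assay, at which 2 of the 3 values shown sit. Compound 4 `CSCC[C@H](NC(=O)c1ccc(NCc2cncn2Cc2cccc(Cl)c2)cc1-c1ccccc1)C(=O)O` differs from compound 1 by the change (chloro in place of cyano on an aromatic carbon). Among the measured compounds shown here, no measured step between compounds exists, so the expected step that the limit leaves unreadable from compound 1 to compound 4 is taken to be none beyond the scatter. Compound 4 is accordingly expected to give 15 uM in this assay, within a range from 5 uM to 50 uM, most likely again as a limit.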

Compound 4, concentration for half-maximal effect: > 10 uM
Compound 4: no number, only a limit; the forecaster's own chance of this, stated with the estimate: 70%; the middle value lies beyond the limit too.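

In this assay, among these compounds, compound 1 and compound 4 each give only a limit, so no step between them can be read: the limit of > 10 uM in this assay, at which 3 of the 4 values shown sit. The compounds shown leave open whether chloro and cyano on the shared core differ at all in this assay.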